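The compounds below may be only part of what the source reports. "The series", "measured", "known", "first", "only" and "open" are said of these compounds alone.

Compound 1, `CNCc1cn(S(=O)(=O)c2cccs2)c(-c2cccnc2F)c1F`, gives 98% in a functional assay on the whole organism (strain Jcl:Sprague-Dawley) for inhibition, with Rattus norvegicus as the target, with stated times of 3 min and 3 h, at a dose of 1 mg/kg by the intravenous route (on this read-out higher numbers stand for more inhibition at the one dose given (going by the name of the read-out) and lower numbers for less inhibition), the highest of the three numbers recorded, although both companions lie within the usual scatter of it. Compound 2, `CNCc1cn(S(=O)(=O)c2ccc(OC)cn2)c(-c2cccnc2F)c1F`, gives 95%, and the step from compound 1 is a number 3 percentage points lower from compound 1 to compound 2 (within the scatter). Compound 3, `CNCc1cn(S(=O)(=O)c2cccc(C)n2)c(-c2cccnc2F)c1F`, gives 91%, with a number 7 percentage points lower from compound 1 to compound 3 (within the scatter); between compound 2 and compound 3 the step is a number 4 percentage points lower from compound 2 to compound 3 (within the scatter). Compound 4, `CNCc1cn(S(=O)(=O)c2ccc(F)cn2)c(-c2cccnc2F)c1F`, has not been measured. It differs from compound 1 as follows: 5-fluoropyridin-2-yl in place of thiophen-2-yl on a sulfonyl sulfur. The two measured steps that bear on it are those that also replace thiophen-2-yl on the sulfonyl sulfur by a substituted pyridin-2-yl, namely a number 3 percentage points lower from compound 1 to compound 2 (within the scatter) and a number 7 percentage points lower from compound 1 to compound 3 (within the scatter), both small. Compound 4 is therefore expected to stay within the scatter of compound 1, and the expected step is a number 4 percentage points lower from compound 1 to compound 4 (within the scatter). The estimate for compound 4 is 94%, with a range from 84% to 99%.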

Compound 4, a percentage reported as inhibition, in the whole organism at one dose (the size of the read-out at that dose, not a potency): 87%
Estimate against measurement, compound 4: 7 percentage points above, within the range that was stated.
By their numbers in this assay, from the lowest: compounds 4, 3, 2 and 1 (each within the scatter of the next, the first and the last beyond it).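

In this assay, for the compounds shown here, 5-fluoropyridin-2-yl in place of thiophen-2-yl on the sulfonyl sulfur gives the first step at this position that passes beyond the scatter, a number 11 percentage points lower from compound 1 to compound 4 (beyond the scatter), so the position is not wholly indifferent to the group it carries, although the step remains modest. Among the substituted pyridin-2-yl compounds the change separates nothing, with a number 4 percentage points lower from compound 3 to compound 4 (within the scatter) and, for fluoro in place of methoxy, a number 8 percentage points lower from compound 2 to compound 4 (within the scatter), so the step shows only against thiophen-2-yl. No measurement at hand offers a reason for it.

Going by these compounds, it remains open whether unsubstituted pyridin-2-yl or plain phenyl on the sulfonyl sulfur would stand nearer compound 1 or compound 4. Also open, on these data alone, is how a carboxylic acid or an amine on that ring would fare.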